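The source may report more compounds than this note shows. Statements on the series, on what has been measured and on what is new or still open speak of the compounds shown alone.

Three compounds sharing the core of compound 1 `COc1cc(-c2nccn2C)cc(OC)c1OC` were examined in a functional assay on T47D cells (Homo sapiens) for antiproliferative activity, read by MTT assay, with a stated time of 72 h; on this read-out lower numbers stand for stronger inhibition and higher numbers for weaker inhibition. In this assay compound 1 gives only the limit of the assay, > 100000 nM. Compound 2 `CCCn1ccnc1-c1cc(OC)c(OC)c(OC)c1` likewise gives in this assay the limit > 100000 nM. Compound 3 `CCCCn1ccnc1-c1cc(OC)c(OC)c(OC)c1` also gives in this assay the limit > 100000 nM. The steps between them are accordingly unreadable: a step that the two limits leave unreadable from compound 1 to compound 2, a step that the two limits leave unreadable from compound 1 to compound 3 and a step that the two limits leave unreadable from compound 2 to compound 3. Compound 3 thus stands at the assay limit together with the other two, as the limit of > 100000 nM in this assay, at which 3 of the 3 values shown sit, records.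

Compound 4 `COc1cc(-c2nccn2-c2ccc(C)cc2)cc(OC)c1OC` differs from compound 3 by 4-methylphenyl in place of butyl on an aromatic nitrogen. Among the compounds with values here, none of the measured steps can be read, so they give no size for this change, and the measured values offer no direction either; the only thing known is that every measured compound sits at the limit.

With that in mind, compound 4 is expected to give roughly 100000 nM in this assay, within 20000 nM to 300000 nM. This estimate means an expected step of a number no higher from compound 3 to compound 4 (the limit leaves the size open), with a substantial chance that only a limit is again reported.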

Compound 4, half-maximal inhibitory concentration: 20500 nM
Beside the measured number, compound 4's estimate is 4.9-fold (0.69 log units) above it; the range from low to high includes it.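

In this assay, 4-methylphenyl on the aromatic nitrogen gives the first value in this series that is not a limit, which shows that this position can affect the read-out, whereas methyl, propyl and butyl there all leave the compounds at the same limit: the limit of > 100000 nM in this assay, at which 3 of the 4 values shown sit.

The change to 4-methylphenyl amounts to an at least 4.8-fold lower number from compound 3 to compound 4 (0.68 log units; beyond the scatter), to an at least 4.8-fold lower number from compound 2 to compound 4 (0.68 log units; beyond the scatter) and to an at least 4.8-fold lower number from compound 1 to compound 4 (0.68 log units; beyond the scatter). Each size is bounded on one side only, and the steps among the three chain compounds remain unreadable.

The compounds shown do not separate the contribution of the six-membered aromatic ring from that of its methyl group, a question that plain phenyl or 4-methoxyphenyl on the same nitrogen would address. They also leave open how large the true step is.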